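Swapping the Imidazole Substituents on a Diphenyl Amide

The source may hold more compounds than are shown below. What is called first, only, known or untested is meant among the compounds shown, and "the series" means these compounds.

Compound 1 `c1ccc(C(CCN2CCCCC2)c2ccccc2)cc1`: 69.6 nM
Compound 2 `CCCc1nccn1CCC(C(N)=O)(c1ccccc1)c1ccccc1`: 177 nM

In an assay on ileum with muscarinic acetylcholine receptor M3 (Cavia porcellus) as the target (a higher number here means a weaker inhibitor, a lower number a stronger inhibitor), compound 1 gives 69.6 nM, while compound 2 gives 177 nM, the higher of the two numbers and a gap beyond the usual scatter. Compound 3 `Cc1ncn(CCC(C(N)=O)(c2ccccc2)c2ccccc2)c1C` has not yet been measured. It differs from compound 2 by 4,5-dimethyl-1H-imidazol-1-yl in place of 2-propyl-1H-imidazol-1-yl on a saturated chain carbon, three bonds along the chain from two aromatic carbons and a carbonyl carbon. Going by the values given here, no measured pair shows this kind of change, so the expectation rests on the change itself: the expected step is a 1.1-fold higher number from compound 2 to compound 3 (0.05 log units; within the scatter), a shift not beyond the scatter in either direction. Compound 3 is therefore estimated at 200 nM, with a range from 80 nM to 500 nM.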

Compound 3, antagonist equilibrium constant: 2.7 nM
The estimate for compound 3 lay 74-fold (1.87 log units) above the measured number; measured number below the stated range.
By their numbers in this assay, from the lowest: compound 3; then compound 1; then compound 2.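

In this assay, the substituents on the imidazole at this saturated chain carbon prove decisive: 4,5-dimethyl-1H-imidazol-1-yl in place of 2-propyl-1H-imidazol-1-yl gives a 66-fold lower number from compound 2 to compound 3 (1.82 log units; beyond the scatter) and makes compound 3 the lowest of the three. Both groups are five-membered aromatic rings with the same hydrogen-bond counts, so those counts do not predict the step. Nothing available explains its size.

As far as these compounds go, removing the propyl group and adding the two methyl groups happened in a single change, so their separate contributions remain unknown. An imidazole bearing a single methyl group, or none, could separate them.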